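Spiro series, aryl change on the ring amide nitrogen

A few compounds are considered here, and "the series" means these few. Any claim that something is new, unique, unknown or untested is made for them only; others in the source may bear on it.

Measured so far:
- compound 1 `CN(C)c1ccc(N2C(=O)NC3(CSC4=C3C(=O)c3ncccc3C4=O)C2=O)cc1`: 20 nM
- compound 2 `O=C1NNC(=O)C2(CSC3=C2C(=O)c2ncccc2C3=O)N1`: 1580 nM; 1600 nM; 1600 nM (3 entries)
- compound 3 `O=C1NN(c2ccccc2)C(=O)C2(CSC3=C2C(=O)c2ncccc2C3=O)N1`: 550 nM

In a functional assay on HT-29 cells (Homo sapiens) for antiproliferative activity, read by MTT assay, with a stated time of 96 h (a higher number here means a weaker inhibitor, a lower number a stronger inhibitor), compound 1 gives the lowest number of the two single values in the set. Compound 3 stands above it by a margin beyond the scatter, and compound 2 stands higher still; the repeat entries of compound 2 the several entries of compound 2 in this assay, 1580 nM; 1600 nM; 1600 nM (3 entries) agree closely with one another. No two of these compounds differ in only one place, so no measured step is available, and the values of compound 2 and compound 3 say only that the unsubstituted and the phenyl-bearing variants sit well above compound 1.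

Compound 4 `O=C1C2=C(C(=O)c3ncccc31)C1(CS2)NC(=O)N(c2ccncc2)C1=O` is not yet measured in this assay. It differs from compound 1 as follows: pyridin-4-yl in place of 4-(dimethylamino)phenyl on an amide-type nitrogen in a ring. The smaller aromatic group without the dimethylamino substituent is expected to cost potency, giving a step from compound 1 to compound 4 of a 5.0-fold higher number from compound 1 to compound 4 (0.70 log units; beyond the scatter), beyond the scatter but short of the gap to compound 3. Compound 4 is therefore estimated at 100 nM, within a range of 25 nM to 400 nM.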

Compound 4, half-maximal inhibitory concentration: 2 nM
Beside the measured number, compound 4's estimate is 50-fold (1.70 log units) above it, outside the stated range (below it).
By their numbers in this assay, from the lowest: compound 4; then compound 1; then compound 3.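

Pyridin-4-yl in place of 4-(dimethylamino)phenyl on the amide-type nitrogen in the ring gives a 10-fold lower number from compound 1 to compound 4 (1.00 log units; beyond the scatter) in this assay, the first measured step at this position. The 4-(dimethylamino)phenyl group is therefore not required for a low number in this assay: the step runs towards the lower number even though the entering group has 6 heavy atoms and the leaving group 9. No measurement shown gives a reason for this step.

From the compounds shown here alone, it remains open whether the ring nitrogen of pyridin-4-yl or the loss of the dimethylamino substituent accounts for the step; a plain phenyl or a pyridin-3-yl group on this same nitrogen of the core of compound 1 would separate the two. Going by these compounds, how far the position tolerates other groups, such as a morpholine or a carboxylic acid on the aromatic ring, also stays open.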